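The source may report more compounds than this note shows. Statements on the series, on what has been measured and on what is new or still open speak of the compounds shown alone.

Measured so far in a functional assay on IMR-32 cells (Homo sapiens) for cytotoxicity, read by sulforhodamine B assay, with a stated time of 48 h; a higher number here means a weaker inhibitor, a lower number a stronger inhibitor:
compound 1, `CC1=C(/C=C/C(=O)/C=C/c2ccccc2)C(C)(C)CCC1`, gives 20400 nM;
compound 2, `CC1=C(/C=C/C(=O)/C=C/c2ccccc2Br)C(C)(C)CCC1`, gives 16300 nM;
compound 3, `COc1ccc(/C=C/C(=O)/C=C/C2=C(C)CCCC2(C)C)cc1OC`, gives 29200 nM.

Compound 1 stands second highest of these three numbers, yet all three lie close together: compound 2 sits nearest, and the step of a 1.3-fold lower number from compound 1 to compound 2 (0.10 log units; within the scatter) is within the scatter, while compound 3 gives a number that differs from compound 1 by no more than the scatter either.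

The next compound, compound 4, `CC1=C(/C=C/C(=O)/C=C/c2cccnc2)C(C)(C)CCC1`, keeps the shared core of compound 1 and changes only the group at its far end: pyridin-3-yl in place of phenyl on a double-bonded chain carbon bound to a double-bonded chain carbon.

Among the compounds with values here, only one measured step touches the same part of the molecule, namely a 1.3-fold lower number from compound 1 to compound 2 (0.10 log units; within the scatter), in which the phenyl was kept but carried a bromo. Compound 3, with two methoxy groups on its phenyl, shows a number within the scatter of compound 1 as well. Within the data shown here, the replacement of phenyl by pyridin-3-yl has no direct precedent here, so the expectation rests on these two neighbours alone. On that basis the step expected in this assay is a 1.0-fold higher number from compound 1 to compound 4 (0.01 log units; within the scatter), no change beyond the scatter.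

Compound 4 is therefore estimated at 21000 nM in this assay.

The expected range for compound 4 runs from 8000 nM to 55000 nM.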

Compound 4, half-maximal inhibitory concentration: 25300 nM
Beside the measured number, compound 4's estimate is 1.2-fold (0.08 log units) below it, and the stated range covers the measured number.
By their numbers in this assay, from the lowest: compounds 2, 1, 4 and 3 (each within the scatter of the next).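

In this assay, the swap of phenyl for pyridin-3-yl brings one ring nitrogen and one hydrogen-bond acceptor into the far end of the molecule, and it gives a 1.2-fold higher number from compound 1 to compound 4 (0.09 log units; within the scatter) with the shared core unchanged. The comparison with the bromo-bearing ring reads the same way, with a 1.6-fold higher number from compound 2 to compound 4 (0.19 log units; within the scatter) for pyridin-3-yl in place of 2-bromophenyl, so neither step at this position moves the number beyond the scatter. Adding an acceptor to this ring therefore leaves the reading in this cell assay where it was, and no supporting measurement is available to interpret this further.

As far as these compounds go, what remains open is whether any group at this place can shift the number beyond the scatter. A ring carrying an amine or a carboxylic acid, or a longer chain in place of the ring, would test this.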